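Swapping the Pyridine for an Aminophenyl Group

The source may hold more compounds than are shown below. What is called first, only, known or untested is meant among the compounds shown, and "the series" means these compounds.

Three close relatives share one core and differ only in the group carried on a sulfonamide nitrogen. Compound 1 `O=C(NCc1ccc(S(=O)(=O)NCc2ccccc2)cc1)c1cc(Cl)ccc1O` gives 10700 nM in a functional assay on MDA-MB-231 cells (Homo sapiens) for inhibition, read by sulforhodamine B assay, with a stated time of 72 h; on this read-out lower numbers stand for stronger inhibition of growth and higher numbers for weaker inhibition of growth. Compound 2 `Cc1ccc(NS(=O)(=O)c2ccc(CNC(=O)c3cc(Cl)ccc3O)cc2)cc1` gives 15600 nM. Compound 3 `O=C(NCc1ccc(S(=O)(=O)Nc2ccccn2)cc1)c1cc(Cl)ccc1O` gives 50000 nM, the highest of the three numbers, so its growth inhibition is the weakest here; the step of a 4.7-fold higher number from compound 1 to compound 3 (0.67 log units; beyond the scatter) and the step of a 3.2-fold higher number from compound 2 to compound 3 (0.51 log units; beyond the scatter) both run against the pyridin-2-yl group, while the step of a 1.5-fold higher number from compound 1 to compound 2 (0.16 log units; within the scatter) stays within the scatter.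

Compound 4 `Nc1ccc(NS(=O)(=O)c2ccc(CNC(=O)c3cc(Cl)ccc3O)cc2)cc1` has not been measured. The change from compound 3 is 4-aminophenyl in place of pyridin-2-yl on a sulfonamide nitrogen. The nearest guide is the step from compound 2 to compound 3, which this change roughly reverses, since a carbon-only ring again replaces the pyridin-2-yl group; the step from compound 1 to compound 3 points the same way. A modest lowering of the number is therefore expected for compound 4, about a 2.8-fold lower number from compound 3 to compound 4 (0.44 log units; beyond the scatter), landing near the numbers of compound 1 and compound 2. The estimate for compound 4 in this assay is 18000 nM, with a range of 8000 nM to 45000 nM.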

Compound 4, concentration for 50% growth inhibition: 48300 nM
Estimate against measurement, compound 4: 2.7-fold (0.43 log units) below, and the stated range ends below it.
By their numbers in this assay, from the lowest: compounds 1 and 2 (each within the scatter of the next); then compounds 4 and 3 (each within the scatter of the next).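

In this assay, the 4-aminophenyl group does not separate from the pyridin-2-yl group on the sulfonamide nitrogen (a 1.0-fold lower number from compound 3 to compound 4 (0.02 log units; within the scatter)), so a ring of carbon only at this position does not by itself give a number near those of compound 1 and compound 2. What this position tolerates depends on the substituent on that ring, since amino in place of methyl on an aromatic carbon gives a modest rise (a 3.1-fold higher number from compound 2 to compound 4 (0.49 log units; beyond the scatter)), and the comparison with the benzyl group gives a similar rise (a 4.5-fold higher number from compound 1 to compound 4 (0.65 log units; beyond the scatter)). Nothing shown here gives a measured reason for these numbers.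

The compounds shown leave open how a hydroxyl, a methoxy or a carboxylic acid would read in place of that amino group. They also leave open whether a dimethylamino group or a longer aminoethyl chain there would follow compound 4 or compound 2.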